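The source may report more compounds than this note shows. Statements on the series, on what has been measured and on what is new or still open speak of the compounds shown alone.

Of the compounds shown here, three built on a shared core have been tested in a functional assay on the whole organism with Mus musculus as the target, in the rotarod test; a lower number here means that less compound is needed, a higher number that more compound is needed for the effect. In this assay compound 1 `CN(C(=O)CNC(=O)CN)c1ccc([N+](=O)[O-])cc1C(=O)c1ccccc1Cl` gives 10 mg/kg. Compound 2 `CN(C(=O)CNC(=O)CN)c1ccc([N+](=O)[O-])cc1C(=O)c1ccccc1`, carrying hydrogen in place of chloro on an aromatic carbon, gives 2.94 mg/kg, a step of a 3.4-fold lower number from compound 1 to compound 2 (0.53 log units; beyond the scatter). Compound 3 `CN(C(=O)CNC(=O)CN)c1ccc(Cl)cc1C(=O)c1ccccc1Cl`, carrying chloro in place of nitro on an aromatic carbon, gives 27.7 mg/kg, a step of a 2.8-fold higher number from compound 1 to compound 3 (0.44 log units; beyond the scatter). Compound 3 therefore stands highest of the three numbers, beyond the scatter from compound 1 and, further still, from compound 2.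

Compound 4 `CCCCC(=O)NCC(=O)N(C)c1ccc(Cl)cc1C(=O)c1ccccc1Cl` has not yet been measured. It differs from compound 3 in one place: propyl in place of amino on a saturated chain carbon bound to a carbonyl carbon. For the measured compounds named here, neither of the two measured steps touches this part of the molecule; both concern substituents on aromatic carbons, so no measured step bears directly on the exchange of amino for propyl on the saturated chain carbon bound to a carbonyl carbon. With nothing to guide it, the expected step for compound 4 in this assay is a 1.0-fold higher number from compound 3 to compound 4 (0.00 log units; within the scatter), none beyond the scatter. The estimate for compound 4 is 28 mg/kg, ranging from 10 mg/kg to 80 mg/kg.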

Compound 4, dose for half-maximal effect: 90 mg/kg
Beside the measured number, compound 4's estimate is 3.2-fold (0.51 log units) below it; the whole stated range lies below it.
By their numbers in this assay, from the lowest: compound 2; then compound 1; then compound 3; then compound 4.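

In this assay, amino giving way to propyl on a saturated chain carbon bound to a carbonyl carbon produces a 3.2-fold higher number from compound 3 to compound 4 (0.51 log units; beyond the scatter), which shows that the number also responds at this end of the molecule and not only to the substituents on aromatic carbons. For this pair, the compound carrying amino needs less compound for the effect, and the compound carrying propyl needs more. No measurement shown here accounts for this step.

A single exchange cannot separate the loss of the amino group from the arrival of the propyl chain, so a methyl group or a dimethylamino group at this place would be needed to tell these apart. Going by these compounds, whether the same exchange would move the number similarly with a nitro group on the aromatic ring also remains open.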